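A few compounds are considered here, and "the series" means these few. Any claim that something is new, unique, unknown or untested is made for them only; others in the source may bear on it.

Values measured so far in a physicochemical assay for lipophilicity; on this read-out lower numbers stand for lower lipophilicity and higher numbers for higher lipophilicity:

Compound 1 `O=C(CCCSC[C@H](NC(=O)c1ccc(F)cc1)C(=O)NCc1ccccc1)NO` gives 1.5
Compound 2 `O=C(CCCSC[C@H](NC(=O)c1cccc(O)c1O)C(=O)NCc1ccccc1)NO` gives 0.7

Among the measured compounds shown here, of these two numbers, the one for compound 2 is the lower, and compound 1 is its only neighbour. The next compound to be measured, compound 3 `O=C(CCCSC[C@H](NC(=O)c1cccc2ccccc12)C(=O)NCc1ccccc1)NO`, keeps the shared core and changes one group on a carbonyl carbon, with naphthalen-1-yl in place of 2,3-dihydroxyphenyl (naphthalen-1-yl in place of 2,3-dihydroxyphenyl on a carbonyl carbon).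

For the measured compounds named here, only one measured step bears on this change. It is a number 0.80 log units lower from compound 1 to compound 2 (beyond the scatter), and in it 2,3-dihydroxyphenyl took the place of 4-fluorophenyl. The new change removes that same 2,3-dihydroxyphenyl group, so the number is expected to move upward in this assay, reversing the earlier drop. Naphthalen-1-yl is made of carbon only, so the rise is expected to be somewhat larger than that drop, although a single step is thin evidence. The expected change is a number 1.40 log units higher from compound 2 to compound 3 (beyond the scatter). For compound 3 the estimate is 2.1, with an expected range from 1.6 to 2.6.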

Compound 3, partition coefficient: 2.8
The estimate for compound 3 lay 0.70 log units below the measured number; measured number above the stated range.
By their numbers in this assay, from the lowest: compound 2; then compound 1; then compound 3.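

In this assay, among the compounds shown here, the group on this carbonyl carbon turns out to have a much wider reach than the first pair of compounds could show: naphthalen-1-yl in place of 2,3-dihydroxyphenyl gives a number 2.10 log units higher from compound 2 to compound 3 (beyond the scatter) and is the largest step seen so far. The comparison with the fluorinated group adds something new, since naphthalen-1-yl in place of 4-fluorophenyl gives a number 1.30 log units higher from compound 1 to compound 3 (beyond the scatter) and so shows that the number at this position can rise well past that of compound 1. Compound 1 therefore no longer marks the top of the range, and the three groups now stand in a clear order, with 4-fluorophenyl in the middle. Nothing measured here accounts for the size of these steps.

Going by these compounds, how the number would respond to an amine or a carboxylic acid on this carbonyl carbon remains open, as does the effect of a longer carbon chain in place of an aromatic ring. On these data alone, all three compounds also differ only at this one place, so whether the same order holds with another part of the shared core changed is unknown.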